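Replacing the Methylsulfonyl Group with a Dimethylcarbamoyl Group

The source may report more compounds than this note shows. Statements on the series, on what has been measured and on what is new or still open speak of the compounds shown alone.

Three compounds sharing one core have been examined in a functional assay on HEK293 cells for agonist activity at Free fatty acid receptor 1 (Homo sapiens), read by fluorescence and calcium flux, with a stated time of 10 min; on this read-out lower numbers stand for an effect already at smaller amounts and higher numbers for an effect only at larger amounts of compound. Compound 1 `CC#C[C@@H](CC(=O)O)c1ccc(OC[C@H]2COc3ccc(Br)cc3O2)cc1` gives 210 nM, compound 2 `CC#C[C@@H](CC(=O)O)c1ccc(OC[C@H]2COc3ccc(C#N)cc3O2)cc1` gives 2100 nM, and compound 3 `CC#C[C@@H](CC(=O)O)c1ccc(OC[C@H]2COc3ccc(S(C)(=O)=O)cc3O2)cc1` gives 27200 nM. Compound 3 thus stands highest of the three: the step of a 13-fold higher number from compound 2 to compound 3 (1.11 log units; beyond the scatter) and the step of a 130-fold higher number from compound 1 to compound 3 (2.11 log units; beyond the scatter) both lie beyond the scatter, and the step of a 10-fold higher number from compound 1 to compound 2 (1.00 log units; beyond the scatter) lies in the same direction.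

Compound 4 `CC#C[C@@H](CC(=O)O)c1ccc(OC[C@H]2COc3ccc(C(=O)N(C)C)cc3O2)cc1` differs from compound 3 in one place: dimethylcarbamoyl in place of methylsulfonyl on an aromatic carbon. For the measured compounds named here, no measured pair shows a dimethylcarbamoyl group at this position, so the only bearing comes from the two steps into compound 3, which were large in the unfavourable direction. Because the data show a 13-fold higher number from compound 2 to compound 3 (1.11 log units; beyond the scatter) and a 130-fold higher number from compound 1 to compound 3 (2.11 log units; beyond the scatter), compound 3 is the extreme of the set, and a change away from its methylsulfonyl group is expected to move the number back part of the way. For compound 4 the step of a 2.7-fold lower number from compound 3 to compound 4 (0.43 log units; beyond the scatter) is therefore expected in this assay. Compound 4 is estimated at 10000 nM, within a range from 2500 nM to 40000 nM.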

Compound 4, half-maximal effective concentration: > 30000 nM
Compound 4 was reported as a limit; the forecaster's own chance of this, stated with the estimate: 10%; middle value at least 3.0-fold (0.47 log units) from the limit.
By their numbers in this assay, from the lowest: compound 1; then compound 2; then compound 3. At a limit, above all of these: compound 4.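

In this assay compound 4 is reported only as a limit: the limit of > 30000 nM in this assay, at which 1 of the 4 values shown sits. The step of an at least 1.1-fold higher number from compound 3 to compound 4 (0.04 log units; that floor lies within the scatter) gives only a floor, so the two cannot be put in order, but dimethylcarbamoyl does not bring the number back towards those of the bromo and cyano compounds. The distance from these is clear, with an at least 14-fold higher number from compound 2 to compound 4 (1.15 log units; beyond the scatter) and an at least 140-fold higher number from compound 1 to compound 4 (2.15 log units; beyond the scatter), so among the four groups shown on this aromatic carbon, both of the carbonyl- or sulfonyl-bearing groups stand at the high end of the series.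

On these data alone, how far the true number of compound 4 lies past its limit remains open. So does how chloro, methyl, methoxy or an unsubstituted carboxamide on this aromatic carbon would compare with bromo.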